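Straightening the Alkyl Chain on a Shared Core

This account rests on a few compounds, and the source may have more. Where it says the series, first, only, none or still open, it means among the compounds named here.

Measured compounds:
compound 1 `[O-][n+]1nc(NCOCc2ccc(Cl)cc2)[n+]([O-])c2ccccc21` — 5100 nM
compound 2 `COc1ccc(COCNc2n[n+]([O-])c3ccccc3[n+]2[O-])cc1` — 52800 nM
compound 3 `CC(C)CCOCNc1n[n+]([O-])c2ccccc2[n+]1[O-]` — 7520 nM

In a functional assay on PC-3 cells (Homo sapiens) for cytotoxicity, read by MTT assay, with a stated time of 72 h (a higher number here means a weaker inhibitor, a lower number a stronger inhibitor), compound 3 gives 7520 nM. Its number sits well apart from compound 2, as a 7.0-fold lower number from compound 2 to compound 3 (0.85 log units; beyond the scatter) shows, but close to compound 1, since a 1.5-fold higher number from compound 1 to compound 3 (0.17 log units; within the scatter) stays within the scatter. Compound 4 `CCCCCOCNc1n[n+]([O-])c2ccccc2[n+]1[O-]` keeps the same atoms and differs from compound 3 only in how the alkyl chain is joined: propyl in place of isopropyl on a saturated chain carbon, two bonds along the chain from an oxygen on a saturated carbon. For the measured compounds named here, none of the measured steps covers such a change; a 10-fold higher number from compound 1 to compound 2 (1.02 log units; beyond the scatter) swaps a substituent on an aromatic ring, and a 1.5-fold higher number from compound 1 to compound 3 (0.17 log units; within the scatter) and a 7.0-fold lower number from compound 2 to compound 3 (0.85 log units; beyond the scatter) replace an aryl group with the isobutyl chain. Going by the values given here, the one step that touches the alkyl side, a 1.5-fold higher number from compound 1 to compound 3 (0.17 log units; within the scatter), is small. Among the compounds with values here, with no step on record separating branched from straight chains, the estimate for compound 4 is a step of a 1.1-fold lower number from compound 3 to compound 4 (0.03 log units; within the scatter), expected to lie within the scatter. Compound 4 is therefore expected at 7000 nM, with a range of 2500 nM to 20000 nM.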

Compound 4, half-maximal inhibitory concentration: 8510 nM
The estimate for compound 4 lay 1.2-fold (0.08 log units) below the measured number, and the stated range covers the measured number.
By their numbers in this assay, from the lowest: compounds 1, 3 and 4 (each within the scatter of the next); then compound 2.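

In this assay the isopropyl-to-propyl change, on a saturated chain carbon two bonds along the chain from an oxygen on a saturated carbon, gives a 1.1-fold higher number from compound 3 to compound 4 (0.05 log units; within the scatter) and thus shows that straightening the chain with the same atoms leaves the number within the scatter. The straight chain also keeps the alkyl side's relation to both aryl groups, with a 1.7-fold higher number from compound 1 to compound 4 (0.22 log units; within the scatter) on replacing 4-chlorophenyl and a 6.2-fold lower number from compound 2 to compound 4 (0.79 log units; beyond the scatter) on replacing 4-methoxyphenyl. No measurement at hand accounts for these results.

The compounds shown leave open whether a longer chain, or a chain ending in an amine or a carboxylic acid, would stay within the scatter of compound 4. As far as these compounds go, whether a fluoro or a nitrile group in place of the chloro of compound 1 would track compound 1 or compound 2 also stays open.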